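The source may hold more compounds than are shown below. What is called first, only, known or untested is meant among the compounds shown, and "the series" means these compounds.

In a physicochemical assay for solubility, using the shake flask method, in simulated intestinal fluid, measured as kinetic solubility, with a stated time of 2 h, at 25 degrees C, at pH 6.5 (on this read-out higher numbers stand for higher solubility and lower numbers for lower solubility), compound 1 `Cc1noc(-c2nc(C)c3c(c2N)C(=O)N(Cc2ccc(F)cc2)C3=O)n1` gives < 5000 nM, which is a limit and not a number. Compound 2 `COc1cccc(CN2C(=O)c3c(C)nc(-c4nc(C)no4)c(N)c3C2=O)c1` gives < 5000 nM, also a limit. Compound 3 `Cc1noc(-c2nc(C)c3c(c2N)C(=O)N(Cc2ccc(OC(F)F)cc2)C3=O)n1` gives < 5000 nM, a limit as well. Compound 3 therefore stands with the other two at one shared reading: the limit of < 5000 nM in this assay, at which 3 of the 3 values shown sit. Compound 4 `Cc1noc(-c2nc(C)c3c(c2N)C(=O)N(Cc2ccc(N(C)C)cc2)C3=O)n1` carries dimethylamino in place of difluoromethoxy on an aromatic carbon, para to a large group: dimethylamino in place of difluoromethoxy on an aromatic carbon. Within the data shown here, three measured steps bear on this change. The closest is a step that the two limits leave unreadable from compound 1 to compound 3, since it also exchanges a group on an aromatic carbon. The other two are a step that the two limits leave unreadable from compound 1 to compound 2 and a step that the two limits leave unreadable from compound 2 to compound 3. None of them offers a size to carry over, so no step beyond the scatter, in either direction, is expected in this assay. The expected change is a step that the limit leaves unreadable from compound 3 to compound 4. The estimate for compound 4 is 3000 nM, with an expected range from 800 nM to 6000 nM.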

Compound 4, solubility: 7400 nM
The estimate for compound 4 lay 2.5-fold (0.39 log units) below the measured number; the whole stated range lies below it.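

Among these compounds, compound 4 is the first compound here to give a number rather than a limit in this assay, and that makes steps to it readable for the first time: the limit of < 5000 nM in this assay, at which 3 of the 4 values shown sit. On this aromatic carbon, dimethylamino gives an at least 1.4-fold higher number from compound 3 to compound 4 (0.17 log units; that floor lies within the scatter) and, set against fluoro, an at least 1.4-fold higher number from compound 1 to compound 4 (0.17 log units; that floor lies within the scatter), while 4-(dimethylamino)phenyl set against 3-methoxyphenyl gives an at least 1.4-fold higher number from compound 2 to compound 4 (0.17 log units; that floor lies within the scatter). Each of these sizes is only a floor, and each floor lies within the scatter, so the change at this place has a direction but no proven size.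

From the compounds shown here alone, the steps among compound 1, compound 2 and compound 3 still cannot be read, so how far apart those three stand remains unknown. Going by these compounds, whether a plain amino group, a morpholine or a carboxylic acid on this aromatic carbon would also give a number remains open.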